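Swapping a Trifluoromethyl for Fluorine on the Benzoyl Ring

The compounds below may be only part of what the source reports. "The series", "measured", "known", "first", "only" and "open" are said of these compounds alone.

Compound 1 `O=[N+]([O-])c1ccc(/N=N/Nc2ccc([N+](=O)[O-])cc2Cl)c(Cl)c1`: 3010 nM
Compound 2 `CC(=O)N(/N=N/c1ccc([N+](=O)[O-])cc1Cl)c1ccc([N+](=O)[O-])cc1Cl`: 630 nM
Compound 3 `O=C(c1cccc(C(F)(F)F)c1)N(/N=N/c1ccc([N+](=O)[O-])cc1Cl)c1ccc([N+](=O)[O-])cc1Cl`: 1180 nM

In a functional assay on HeLa cells (Homo sapiens) for cytotoxicity, read by MTT assay, with a stated time of 72 h (a higher number here means a weaker inhibitor, a lower number a stronger inhibitor), compound 3 sits second highest of the three numbers; its closest neighbour is compound 2, separated by a 1.9-fold higher number from compound 2 to compound 3 (0.27 log units; within the scatter), a gap within the scatter, while compound 1 lies further off. Compound 4 `O=C(c1cccc(F)c1)N(/N=N/c1ccc([N+](=O)[O-])cc1Cl)c1ccc([N+](=O)[O-])cc1Cl` is compound 3 with one change: fluoro in place of trifluoromethyl on an aromatic carbon. Going by the values given here, the only measured step that touches this part of the molecule is a 1.9-fold higher number from compound 2 to compound 3 (0.27 log units; within the scatter), which stayed within the scatter, whereas a 4.8-fold lower number from compound 1 to compound 2 (0.68 log units; beyond the scatter) concerned a different position. Shrinking one substituent on the same ring is therefore expected to move this assay little, if at all. Compound 4 is estimated at 1100 nM, with a likely range from 500 nM to 2500 nM, meaning an expected step of a 1.1-fold lower number from compound 3 to compound 4 (0.03 log units; within the scatter).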

Compound 4, half-maximal inhibitory concentration: 2500 nM
For compound 4 the middle estimate is 2.3-fold (0.36 log units) below the measured one, and the stated range covers the measured number.
By their numbers in this assay, from the lowest: compounds 2 and 3 (each within the scatter of the next); then compounds 4 and 1 (each within the scatter of the next).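

Fluoro in place of trifluoromethyl gives a 2.1-fold higher number from compound 3 to compound 4 (0.33 log units; beyond the scatter) in this assay, so this ring position is less indifferent than the earlier compounds suggested. Going by these compounds alone, changing methyl to 3-fluorophenyl on the carbonyl gives a 4.0-fold higher number from compound 2 to compound 4 (0.60 log units; beyond the scatter), a step that is clearer than the one to compound 3. Adding the whole (3-fluorophenyl)carbonyl group in place of hydrogen on the nitrogen gives a 1.2-fold lower number from compound 1 to compound 4 (0.08 log units; within the scatter), so this acyl group leaves the number where the amide hydrogen had it. No measurement here explains these shifts. On these data alone, whether a methoxy group or an amine on this ring carbon would match compound 3 or compound 4 remains open.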